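Halogen trimming on the aryl tail of the amide series

A few compounds are considered here, and "the series" means these few. Any claim that something is new, unique, unknown or untested is made for them only; others in the source may bear on it.

Measured so far:
compound 1 `COc1cccc(CCC(=O)Nc2nc3ccccc3c(=O)s2)c1` — 1370 nM
compound 3 `COc1cccc(/C=C/CC(=O)Nc2nc3ccccc3c(=O)s2)c1` — 500 nM
compound 2 `O=C(CCCc1ccc(Cl)c(Cl)c1)Nc1nc2ccccc2c(=O)s1` — "not determined" (no result reported)

In an assay on CHO cells for displacement of a labelled ligand from adenosine receptor A1 (Homo sapiens), read by scintillation counting, with a stated time of 90 min (on this read-out higher numbers stand for weaker inhibition and lower numbers for stronger inhibition), compound 1 gives 1370 nM and compound 3 gives 500 nM. For compound 2 this assay records "not determined" (no result reported), so it stands nowhere on the scale set by compound 1 and compound 3; it carries a 3,4-dichlorophenyl tail on the shared core.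

Compound 4 `O=C(CCCc1cccc(Cl)c1)Nc1nc2ccccc2c(=O)s1` follows from compound 2 by hydrogen in place of chloro on an aromatic carbon. For the measured compounds named here, with no measured pair showing this change, no step size or direction can be drawn; the working assumption is a change no larger than the usual scatter. Compound 4 is expected to fall near 900 nM, between 200 nM and 4000 nM.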

Compound 4, inhibition constant: > 10000 nM
Compound 4 ended at the assay's limit; the forecaster's own chance of this, stated with the estimate: 15%; middle value at least 11-fold (1.04 log units) away from the limit.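

In this assay compound 4 reads > 10000 nM, which is a limit of the assay and not a number. For the compounds shown here, putting 3-chlorobenzyl in place of 3-methoxyphenyl on the saturated chain gives an at least 7.2-fold higher number from compound 1 to compound 4 (0.86 log units; beyond the scatter) and is the first step in these notes to reach that limit. The aryl tail on the shared core is therefore not freely exchangeable.

The step from 3,4-dichlorophenyl to 3-chlorophenyl cannot be read, as compound 2 has no number. On these data alone, whether an amine or a carboxylic acid on the aryl tail would return a measurable value remains open.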